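Cytotoxicity limits and the pyrimidin-4-yl change

The compounds below may be only part of what the source reports. "The series", "measured", "known", "first", "only" and "open" are said of these compounds alone.

- compound 1 `CC(C)(C)C#Cc1cc(N(C(=O)[C@H]2CC[C@H](C)CC2)[C@H]2CC[C@H](Oc3ccc4nccn4n3)CC2)c(C(=O)O)s1` gives > 20000 nM
- compound 2 `CC1CC=C(C(=O)N(c2cc(C#CC(C)(C)C)sc2C(=O)O)C(C)C)CC1` gives > 20000 nM
- compound 3 `CC(C)N(c1cc(C#CC(C)(C)C)sc1C(=O)O)C(=O)[C@H]1CC[C@H](CF)CC1` gives > 20000 nM

In an ADME assay on MT4 cells (Homo sapiens) for cytotoxicity, with a stated time of 5 days (a higher number here means that more compound is tolerated, a lower number that less compound is tolerated), compound 1 stands at > 20000 nM as a limit and not a number. Going by the values given here, the series shows the limit of > 20000 nM in this assay, at which 3 of the 3 values shown sit, and no measured number so far. Among the compounds with values here, the only measured step is a step that the two limits leave unreadable from compound 2 to compound 3 and it has no readable size. Compound 4 `CC(C)(C)C#Cc1cc(N(C(=O)[C@H]2CC[C@H](C)CC2)[C@H]2CC[C@H](Oc3ccncn3)CC2)c(C(=O)O)s1` differs from compound 1 by a group of 6 heavy atoms (4 carbon, 2 nitrogen; one six-membered aromatic ring with 2 hetero atoms) in place of a group of 9 heavy atoms (6 carbon, 3 nitrogen; one five-membered aromatic ring with 2 hetero atoms, one six-membered aromatic ring with 2 hetero atoms), on an oxygen on a saturated carbon with pyrimidin-4-yl entering on an oxygen on a saturated carbon. Within the data shown here, no measured step covers this change. With compound 1 at > 20000 nM as a limit, no step beyond the scatter is expected in this assay for this change. The estimated step is a number no higher from compound 1 to compound 4 (the limit leaves the size open) on this reading. Compound 4 is expected at 20000 nM with an estimated range from 10000 nM to 40000 nM and probably as a limit again.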

Compound 4, half-maximal cytotoxic concentration: > 20000 nM
Compound 4 gave a limit, no number; the forecaster's own chance of this, stated with the estimate: 85%; the middle value lies on the limit itself.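

Compound 1 and compound 4 both give only limits in this assay, and the step between them cannot be read. The compounds shown leave open at what concentration any of them stops being tolerated: the limit of > 20000 nM in this assay, at which 4 of the 4 values shown sit.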